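Stripping the Acyl Group Down to a Free Amine

The compounds below may be only part of what the source reports. "The series", "measured", "known", "first", "only" and "open" are said of these compounds alone.

Three compounds share one core and differ only in the group attached to a nitrogen on an aromatic ring. In an assay on CHO cells for displacement of a labelled ligand from adenosine receptor A1 (Homo sapiens), tested at 10 uM (a higher number here means more inhibition at the concentration tested (going by the name of the read-out), a lower number less inhibition), compound 1 `O=C(Nc1nn(-c2ccccc2)c(=O)c2ccccc12)c1ccccc1` gives 44%. Compound 2 `O=C(Nc1nn(-c2ccccc2)c(=O)c2ccccc12)c1ccc(Cl)cc1` gives 26%, and compound 3 `O=C(Nc1nn(-c2ccccc2)c(=O)c2ccccc12)c1ccco1` gives 23%, the lowest of the three numbers, although its gap to compound 2 lies within the scatter. The measured steps were a number 18 percentage points lower from compound 1 to compound 2 (beyond the scatter), a number 21 percentage points lower from compound 1 to compound 3 (beyond the scatter) and a number 3 percentage points lower from compound 2 to compound 3 (within the scatter). Compound 4 `Nc1nn(-c2ccccc2)c(=O)c2ccccc12` goes further than any of these: hydrogen in place of (furan-2-yl)carbonyl on a nitrogen on an aromatic ring. Among the compounds with values here, no measured step removes the whole carbonyl group, so the two steps that merely exchanged it, both modest drops, offer only loose guidance. A further modest fall is expected, a number 8 percentage points lower from compound 3 to compound 4 (within the scatter). Compound 4 is therefore estimated at 15%, within 0% to 35%.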

Compound 4, a percentage reported as inhibition, at one concentration (the size of the read-out at that concentration, not a potency): 24%
For compound 4 the middle estimate is 9 percentage points below the measured one, within the range that was stated.
By their numbers in this assay, from the lowest: compounds 3, 4 and 2 (each within the scatter of the next); then compound 1.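

Taking the whole acyl group off the nitrogen leaves a free amino group, and the result in this assay sits level with two of the amides: a number 1 percentage points higher from compound 3 to compound 4 (within the scatter) and a number 2 percentage points lower from compound 2 to compound 4 (within the scatter). Only the benzoyl compound stands apart, with a number 20 percentage points lower from compound 1 to compound 4 (beyond the scatter), so here the plain amino group cannot be told from the (furan-2-yl)carbonyl or (4-chlorophenyl)carbonyl amides. Nothing available explains why benzoyl alone stands apart. On these data alone, it remains open whether a small acetyl group on this nitrogen would read like compound 1 or like compound 4, and how a methoxy group in place of the chloro would read.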